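The source may hold more compounds than are shown below. What is called first, only, known or untested is meant among the compounds shown, and "the series" means these compounds.

Three measured compounds share one core and differ only in the group attached to the thiocarbonyl carbon. Compound 1 `Nc1ccccc1NC(=O)c1ccc(CSC(=S)N2CCc3ccccc32)cc1` carries a 2,3-dihydro-1H-indol-1-yl group there; in a functional assay on MGC-803 cells (Homo sapiens) for antiproliferative activity, read by CCK-8 assay, with a stated time of 72 h, tested at 8 uM (a lower number here means a weaker effect, a higher number a stronger effect of the compound at the concentration tested), compound 1 gives 87%. Compound 2 `Nc1ccccc1NC(=O)c1ccc(CSC(=S)N2CCCc3ccccc32)cc1` carries a 1,2,3,4-tetrahydroquinolin-1-yl group instead, and in this assay compound 2 gives 87.5%, so that a number 0.5 percentage points higher from compound 1 to compound 2 (within the scatter). Compound 3 `CCN(Cc1ccncc1)C(=S)SCc1ccc(C(=O)Nc2ccccc2N)cc1` carries an ethyl((pyridin-4-yl)methyl)amino group; in this assay compound 3 gives 85.2%. That is the lowest of the three numbers, but a number 1.8 percentage points lower from compound 1 to compound 3 (within the scatter) and a number 2.3 percentage points lower from compound 2 to compound 3 (within the scatter), so this measurement does not tell the three compounds apart.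

Compound 4 `CN(Cc1ccncc1)C(=S)SCc1ccc(C(=O)Nc2ccccc2N)cc1` is compound 3 with a single change: hydrogen in place of methyl on a saturated chain carbon bound to an amide-type nitrogen. For the measured compounds named here, none of the measured steps removes one carbon in this way; all three exchange the whole group on the thiocarbonyl carbon, and even those larger exchanges stayed within the scatter. With nothing pointing the other way, the expected step is small, a number 0.2 percentage points lower from compound 3 to compound 4 (within the scatter), in no particular direction. Compound 4 is therefore estimated to give 85% in this assay, within a range from 75% to 92%.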

Compound 4, a percentage reported as inhibition, at one concentration (the size of the read-out at that concentration, not a potency): 83.2%
For compound 4 the middle estimate is 1.8 percentage points above the measured one, within the range that was stated.
By their numbers in this assay, from the lowest: compounds 4, 3, 1 and 2 (each within the scatter of the next).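

For the compounds shown here, exchanging ethyl for methyl in the ethyl((pyridin-4-yl)methyl)amino group is the first change here that removes a single carbon and leaves the rest of the group in place, and in this assay it gives a number 2 percentage points lower from compound 3 to compound 4 (within the scatter) and so does not separate the two chain lengths. The methyl((pyridin-4-yl)methyl)amino group also stays unresolved from the two other groups on the thiocarbonyl carbon, with a number 4.3 percentage points lower from compound 2 to compound 4 (within the scatter) against the 1,2,3,4-tetrahydroquinolin-1-yl group and a number 3.8 percentage points lower from compound 1 to compound 4 (within the scatter) against the 2,3-dihydro-1H-indol-1-yl group, so all four compounds remain indistinguishable in this measurement. No other information is available here that bears on these small steps.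

The compounds shown leave open whether a longer chain such as propyl or butyl in place of the ethyl, or a chain ending in a carboxylic acid, would move the read-out beyond the scatter. They also leave open how these compounds rank in potency, since a percentage at one concentration measures only the size of the effect at that concentration.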